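Swapping the aryl group for isopropyl on the amine

The compounds below may be only part of what the source reports. "The series", "measured", "known", "first", "only" and "open" are said of these compounds alone.

Compound 3 `Cc1ccc(S(=O)(=O)/N=C(/CCNC2=CC(=O)c3ccccc3C2=O)Nc2cc(F)c(F)c(F)c2)cc1`, compound 2 `Cc1ccc(S(=O)(=O)/N=C(/CCNC2=CC(=O)c3ccccc3C2=O)Nc2ccc(F)c(F)c2)cc1` and compound 1 `Cc1ccc(S(=O)(=O)/N=C(/CCNC2=CC(=O)c3ccccc3C2=O)Nc2ccccc2[N+](=O)[O-])cc1` share one core and differ only in the group on the amine nitrogen. In a functional assay on HeLa cells (Homo sapiens) for cytotoxicity, read by MTT assay, with a stated time of 48 h (on this read-out lower numbers stand for stronger inhibition and higher numbers for weaker inhibition), compound 1 gives 3310 nM, compound 2 gives 8790 nM and compound 3 gives 8580 nM. Compound 3 thus sits together with compound 2, the pair separated by a 1.0-fold lower number from compound 2 to compound 3 (0.01 log units; within the scatter), while both lie apart from compound 1: a 2.7-fold higher number from compound 1 to compound 2 (0.42 log units; beyond the scatter) and a 2.6-fold higher number from compound 1 to compound 3 (0.41 log units; beyond the scatter). Compound 4 `Cc1ccc(S(=O)(=O)/N=C(/CCNC2=CC(=O)c3ccccc3C2=O)NC(C)C)cc1` carries isopropyl in place of 3,4,5-trifluorophenyl on an amine nitrogen. Among the measured compounds shown here, no measured step replaces an aromatic ring with an open chain; the two aryl-to-aryl swaps were modest and the single fluorine swap stayed within the scatter. A modest step in either direction is therefore expected, centred near compound 3: a 1.0-fold higher number from compound 3 to compound 4 (0.02 log units; within the scatter). The estimate for compound 4 in this assay is 9000 nM, between 3000 nM and 27000 nM.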

Compound 4, half-maximal inhibitory concentration: 30200 nM
The estimate for compound 4 lay 3.4-fold (0.53 log units) below the measured number; the whole stated range lies below it.
By their numbers in this assay, from the lowest: compound 1; then compounds 3 and 2 (each within the scatter of the next); then compound 4.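

Here, for the first time, the aromatic ring on this amine nitrogen gives way to an open chain, and in this assay the number rises against all three aryl compounds: a 3.5-fold higher number from compound 3 to compound 4 (0.55 log units; beyond the scatter) and a 3.4-fold higher number from compound 2 to compound 4 (0.54 log units; beyond the scatter) and a 9.1-fold higher number from compound 1 to compound 4 (0.96 log units; beyond the scatter). Among these four compounds, then, each aryl group goes with a lower number than isopropyl, and no compound goes against this. Nothing shown explains the rise.

With only one open chain, it remains unclear whether the ring itself or simply the size of the group matters. A cyclohexyl ring or a longer chain such as n-butyl on this nitrogen would help separate the two.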